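A few compounds are considered here, and "the series" means these few. Any claim that something is new, unique, unknown or untested is made for them only; others in the source may bear on it.

Compound 3, `CN(C1CCN(CCCc2c[nH]c3ccc(-n4cnnc4)cc23)CC1)S(=O)(=O)c1ccccc1`, gives 1.5 nM in an assay on CHO cells for displacement of a labelled ligand from 5-hydroxytryptamine receptor 1D (Homo sapiens) (on this read-out higher numbers stand for weaker inhibition and lower numbers for stronger inhibition), the lowest of the three numbers measured; compound 1, `c1ccc(CNCC2CCN(CCCc3c[nH]c4ccc(-n5cnnc5)cc34)CC2)cc1`, gives 1.6 nM, and compound 2, `O[C@@H]1Cc2ccccc2[C@H]1NC1CCN(CCCc2c[nH]c3ccc(-n4cnnc4)cc23)CC1`, gives 6.6 nM. The step from compound 3 to compound 4, `C[C@@H](NC1CCN(CCCc2c[nH]c3ccc(-n4cnnc4)cc23)CC1)c1ccccc1`, is (1-phenylethyl)amino in place of methyl(phenylsulfonyl)amino on a saturated ring carbon. For the measured compounds named here, two measured steps bear on this change. One is a 1.1-fold lower number from compound 1 to compound 3 (0.03 log units; within the scatter), which shows that a secondary amine carrying a phenyl ring, as in compound 1, can match the sulfonamide of compound 3. The other is a 4.4-fold lower number from compound 2 to compound 3 (0.64 log units; beyond the scatter), where a bulkier secondary amine built on a hydroxy-indane gave a weaker result. The incoming (1-phenylethyl)amino group of compound 4 sits between these two cases: a secondary amine bearing one phenyl ring, with a single extra methyl and a defined stereocentre. The step is therefore expected to be small, most likely a slight rise in the number, and compound 4 is estimated at 3 nM, within a range from 1.2 nM to 8 nM, the change being a 2.0-fold higher number from compound 3 to compound 4 (0.30 log units; within the scatter).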

Compound 4, half-maximal inhibitory concentration: 0.4 nM
The estimate for compound 4 lay 7.5-fold (0.88 log units) above the measured number, and the stated range ends above it.
By their numbers in this assay, from the lowest: compound 4; then compounds 3 and 1 (each within the scatter of the next); then compound 2.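

In this assay, the (1-phenylethyl)amino group gives a 3.8-fold lower number from compound 3 to compound 4 (0.57 log units; beyond the scatter), so a secondary amine at this saturated ring carbon can go beyond the level that compound 1 and compound 3 share within the scatter. The group also stands clear of the other two amines, with a 4.0-fold lower number from compound 1 to compound 4 (0.60 log units; beyond the scatter) and, the largest step in the set, a 17-fold lower number from compound 2 to compound 4 (1.22 log units; beyond the scatter), which shows that the result at this position depends on what the amine carries and not merely on an amine being present. No measured evidence explains these differences.

On these data alone, it remains open whether the methyl or the defined stereocentre of compound 4 accounts for its lower number, a question that the opposite stereoisomer and a plain benzylamino group on the same carbon would address. As far as these compounds go, how a (2-phenylethyl)amino group, with its longer chain, would read also remains open.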